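Hydroxy to Methoxy on a Tricyclic Ester Core

The source may hold more compounds than are shown below. What is called first, only, known or untested is meant among the compounds shown, and "the series" means these compounds.

Compound 2, `CC1=C[C@H](OC(=O)c2ccc(O)cc2)[C@@H]2[C@](C)(CC[C@@]2(O)C(C)C)CC1=O`, was tested in a functional assay on SEM cells (Homo sapiens) for cytotoxicity, read by MTT assay, with a stated time of 72 h (a higher number here means a weaker inhibitor, a lower number a stronger inhibitor), and gave 24400 nM. Compound 1, `COc1ccc(C(=O)O[C@H]2CC(C)=C[C@H](OC(C)=O)[C@@]3(C)[C@@H](OC(C)=O)C[C@@](O)(C(C)C)[C@H]23)cc1`, was measured alongside it: in this assay compound 1 gave 15000 nM, a value within the usual scatter of that of compound 2, so the two cannot be told apart. Compound 3, `COc1ccc(C(=O)O[C@H]2C=C(C)C(=O)C[C@@]3(C)CC[C@@](O)(C(C)C)[C@H]23)cc1`, is compound 2 with one change: methyl in place of hydrogen on an oxygen on an aromatic ring. For the measured compounds named here, no measured pair shows this same change, so the expected step from compound 2 to compound 3 is set at a 1.4-fold lower number from compound 2 to compound 3 (0.13 log units; within the scatter), small and not beyond the scatter. For compound 3 the estimate in this assay is 18000 nM, between 7000 nM and 45000 nM.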

Compound 3, half-maximal inhibitory concentration: 28400 nM
For compound 3 the middle estimate is 1.6-fold (0.20 log units) below the measured one, within the range that was stated.
By their numbers in this assay, from the lowest: compounds 1, 2 and 3 (each within the scatter of the next).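

Methyl in place of hydrogen on an oxygen on an aromatic ring gives a 1.2-fold higher number from compound 2 to compound 3 (0.07 log units; within the scatter) in this assay and so 4-hydroxyphenyl and 4-methoxyphenyl cannot be told apart on this core. For the compounds shown here, this is the only measured pair for this change, and it lies within the scatter. No measurement at hand bears on the reason for this result.

Still open, on these data alone, is whether a longer chain such as ethoxy, or an amine or a carboxylic acid, at this place on the aromatic ring would shift the number beyond the scatter. As far as these compounds go, whether hydroxy and methoxy also match on the core of compound 1 remains open too.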